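Oxime ether series: minimum effective dose in mice

A few compounds are considered here, and "the series" means these few. Any claim that something is new, unique, unknown or untested is made for them only; others in the source may bear on it.

Measured so far:
compound 1 `C#CCO/N=C/c1c(-c2ccc(C)cc2)nc2c(C)cccn12` — 20 mg/kg
compound 2 `Cc1ccc(-c2nc3c(C)cccn3c2/C=N/OCc2cn(Cc3ccc([N+](=O)[O-])cc3)nn2)cc1` — 20 mg/kg
compound 3 `COc1ccc(Cn2cc(CO/N=C/c3c(-c4ccccc4)nc4c(C)cccn34)nn2)cc1` — 40 mg/kg

In a functional assay on the whole organism (strain NMRI) with Mus musculus as the target, with a stated time of 0.5 h (a lower number here means that less compound is needed, a higher number that more compound is needed for the effect), compound 1 gives 20 mg/kg. Compound 2 gives 20 mg/kg in this assay, which is the same figure at the digits recorded, so the two stand level. Compound 3 gives 40 mg/kg in this assay, a higher figure than that of compound 1, but the gap lies within the usual scatter, so no order among the three compounds can be read from these numbers. For the measured compounds named here, the three differ from one another in more than one place, and no single-point step between them is counted.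

Compound 4 `Cc1ccc(-c2nc3c(C)cccn3c2/C=N/O)cc1` has not yet been measured in this assay. Relative to compound 1 the change is hydrogen in place of propargyl on an oxygen. Going by the values given here, every measured member carries an ether on the oxime oxygen; a free hydroxy there has no precedent, so the direction of the step rests on no recorded comparison. The step from compound 1 to compound 4 is expected to be a 1.5-fold higher number from compound 1 to compound 4 (0.18 log units; within the scatter), at most a small move toward a higher dose, possibly none beyond the scatter. For compound 4 the expected value in this assay is 30 mg/kg, with a range from 10 mg/kg to 100 mg/kg.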

Compound 4, minimum effective dose: 20 mg/kg
For compound 4 the middle estimate is 1.5-fold (0.18 log units) above the measured one, within the range that was stated.
By their numbers in this assay, from the lowest: compounds 1, 2, 4 and 3 (each within the scatter of the next).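

In this assay, for the compounds shown here, hydrogen in place of propargyl on the oxime oxygen gives no change at the digits printed from compound 1 to compound 4 (within the scatter), the first step that isolates this position. An ether on this oxygen is therefore not needed for a reading at this level: the free hydroxy of compound 4 stands level with the propargyloxy group of compound 1, so removing the 3 carbon atoms and the triple bond leaves the minimum effective dose unmoved within the scatter. Nothing measured alongside these doses bears on why the position tolerates this change.

Still open, going by these compounds, is whether this tolerance extends to other groups on the same oxygen, such as a simple methyl, a longer alkyl chain, a chain ending in an amine or one ending in a carboxylic acid. Also unsettled is whether the same change would read the same way on the core of compound 3, and whether any group at this position can move the dose beyond the scatter in either direction.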